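The source may hold more compounds than are shown below. What is called first, only, known or untested is meant among the compounds shown, and "the series" means these compounds.

Measured so far in the series:
- compound 1, `COc1cc(C)cc(-c2nn(CC#N)cc2-c2ccc(-c3cccc(C(C)=O)c3)nc2)c1`: -17%
- compound 2, `Cc1cc(O)cc(-c2nn(CC#N)cc2-c2ccnc(-c3ccc(Oc4ccccc4)cc3)c2)c1`: -65%
- compound 3, `COc1cc(C)cc(-c2nn(CC#N)cc2-c2ccnc(-c3ccc(N(C)C)cc3)c2)c1`: -13%

All three numbers come from a functional assay on HOP-92 cells (Homo sapiens) for cytotoxicity, read by sulforhodamine B assay, with a stated time of 48 h, tested at 10 uM; a higher number here means a weaker effect of the compound at the concentration tested, a lower number a stronger effect. Compound 3 stands at the highest of the three numbers. Its nearest neighbour is compound 1, whose number lies only a few points lower, within the scatter, so no order between compound 3 and compound 1 can be read. For the measured compounds named here, its furthest neighbour is compound 2, whose number lies far lower, beyond the scatter; compound 2 differs from compound 3 in more than one place, so no single step is recorded between them.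

Compound 4, `Cc1cc(O)cc(-c2nn(CC#N)cc2-c2ccnc(-c3ccc(N(C)C)cc3)c2)c1`, has not yet been measured. It differs from compound 3 by hydrogen in place of methyl on an oxygen on an aromatic ring. Going by the values given here, no step between measured compounds isolates this change. Compound 4 shares its hydroxy-bearing ring with compound 2, which gives -65%, but the two also differ elsewhere, so that number does not settle the question. A step of modest size toward a lower number, a number 12 percentage points lower from compound 3 to compound 4 (beyond the scatter), is expected, with wide uncertainty. For compound 4 the expected value is -25%, in a range from -60% to 5%.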

Compound 4, a percentage reported as activity, at one concentration (the size of the read-out at that concentration, not a potency): -12%
Beside the measured number, compound 4's estimate is 13 percentage points below it, within the range that was stated.
By their numbers in this assay, from the lowest: compound 2; then compounds 1, 3 and 4 (each within the scatter of the next).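

In this assay, the change from methoxy to hydroxy on an aromatic ring gives a number 1 percentage points higher from compound 3 to compound 4 (within the scatter), so with dimethylamino on the other aryl ring this position shows no readable response to losing the methyl. With the hydroxy-bearing ring held constant, dimethylamino in place of phenoxy on an aromatic carbon gives a number 53 percentage points higher from compound 2 to compound 4 (beyond the scatter), which ties the low number of compound 2 to the phenoxy-to-dimethylamino difference and not to the hydroxy group alone. Nothing available explains either step.

Going by these compounds, it remains open whether methoxy and hydroxy would also read alike with phenoxy on that aromatic carbon. On these data alone, it is also open whether a benzyloxy or morpholine group there would fall nearer compound 2 or compound 4.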